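The compounds below may be only part of what the source reports. "The series", "measured", "known", "first", "only" and "open" are said of these compounds alone.

Measured so far in an assay on HEK293 cells for agonist activity at transient receptor potential cation channel subfamily M member 8 (Homo sapiens), read by fluorescence and calcium flux, with a stated time of 15 min; on this read-out lower numbers stand for an effect already at smaller amounts and higher numbers for an effect only at larger amounts of compound:
- compound 1 `Cc1ccc(OCC(=O)N(Cc2cccs2)CC(C)C)cc1`: 900 nM
- compound 2 `Cc1ccc(OCC(=O)N(Cc2cccs2)c2nccs2)cc1`: 2240 nM

Compound 2 has the higher of the two numbers in this assay; the nearest is compound 1, and the step of a 2.5-fold higher number from compound 1 to compound 2 (0.40 log units; beyond the scatter) is the only one measured, with 1,3-thiazol-2-yl in place of isobutyl on the amide-type nitrogen.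

Compound 3 `Cc1ccc(OCC(=O)N(Cc2cccs2)c2ccncc2)cc1` is not yet measured. It differs from compound 2 by pyridin-4-yl in place of 1,3-thiazol-2-yl on an amide-type nitrogen. Among the compounds with values here, no measured step exchanges one aromatic ring for another at this position; the single step of a 2.5-fold higher number from compound 1 to compound 2 (0.40 log units; beyond the scatter) concerns a saturated chain against an aromatic ring and so bears only loosely on this change. Within the data shown here, with no directly comparable step, no shift beyond the scatter is expected in this assay. The expected step is a 1.1-fold higher number from compound 2 to compound 3 (0.05 log units; within the scatter). Compound 3 is therefore estimated at 2500 nM in this assay, with a range from 1000 nM to 6300 nM.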

Compound 3, half-maximal effective concentration: 52 nM
The estimate for compound 3 lay 48-fold (1.68 log units) above the measured number, outside the stated range (below it).
By their numbers in this assay, from the lowest: compound 3; then compound 1; then compound 2.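

In this assay, the group on the amide-type nitrogen can shift the number far more than the first pair showed: pyridin-4-yl in place of 1,3-thiazol-2-yl gives a 43-fold lower number from compound 2 to compound 3 (1.63 log units; beyond the scatter), a large step between two aromatic rings. An aromatic ring at this place therefore has no single effect, as pyridin-4-yl in place of isobutyl gives a 17-fold lower number from compound 1 to compound 3 (1.24 log units; beyond the scatter), while compound 2 goes against this direction with a 2.5-fold higher number from compound 1 to compound 2 (0.40 log units; beyond the scatter). Nothing available explains why these two rings differ so sharply.

How phenyl or pyridin-3-yl would stand on the amide-type nitrogen remains open, so the compounds shown cannot tie the step to the place of the ring nitrogen. Also open, from the compounds shown here alone, is whether the low number of compound 3 would hold with a methoxy group in place of the methyl group on the shared core.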